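Swapping an aromatic group for cyclohexyl in compound 4

The source may report more compounds than this note shows. Statements on the series, on what has been measured and on what is new or still open speak of the compounds shown alone.

Measured in a functional assay on HCT-116 cells (Homo sapiens) for antiproliferative activity, read by MTT assay, with a stated time of 72 h; on this read-out lower numbers stand for stronger inhibition and higher numbers for weaker inhibition:
- compound 1 `O=C(Nc1ccc(Nc2nccc(NC3CCCC3)n2)cc1)Nc1ccc(Cl)c(C(F)(F)F)c1` gives 2510 nM
- compound 2 `O=C(Nc1ccc(Nc2nccc(Nc3ccccc3)n2)cc1)Nc1ccc(Cl)c(C(F)(F)F)c1` gives > 50000 nM, which is a limit of the assay
- compound 3 `O=C(Nc1ccc(Nc2nccc(Nc3ccc(Cl)cc3)n2)cc1)Nc1ccc(Cl)c(C(F)(F)F)c1` gives 4660 nM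

Compound 1 holds one of the two true numbers, and the other stays close to it: a 1.9-fold higher number from compound 1 to compound 3 (0.27 log units; within the scatter). Compound 4 `O=C(Nc1ccc(Nc2nccc(NC3CCCC3)n2)cc1)NC1CCCCC1` keeps the core of compound 1 but has cyclohexyl in place of 4-chloro-3-(trifluoromethyl)phenyl on an amide-type nitrogen. Among the measured compounds shown here, no measured step changes this group, so the evidence is indirect. Two steps were large, an at least 19-fold higher number from compound 1 to compound 2 (1.29 log units; beyond the scatter) and an at least 10-fold lower number from compound 2 to compound 3 (1.03 log units; beyond the scatter). The second, which gained a chloro, is the closest guide, since compound 4 loses one. A weakening in this assay is therefore expected, of moderate size and with wide uncertainty. The expected step is a 4.0-fold higher number from compound 1 to compound 4 (0.60 log units; beyond the scatter). Compound 4 is estimated at 10000 nM, with an expected range of 2500 nM to 45000 nM.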

Compound 4, half-maximal inhibitory concentration: 1090 nM
Beside the measured number, compound 4's estimate is 9.2-fold (0.96 log units) above it, and the stated range ends above it.
By their numbers in this assay, from the lowest: compound 4; then compounds 1 and 3 (each within the scatter of the next). At a limit, above all of these: compound 2.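

With cyclohexyl in place of 4-chloro-3-(trifluoromethyl)phenyl on the amide-type nitrogen, this assay shows a 2.3-fold lower number from compound 1 to compound 4 (0.36 log units; beyond the scatter). Among the compounds shown here, the earlier compounds varied a different place, so this is the first sign that inhibition here does not depend on the aromatic ring, the chlorine or the trifluoromethyl group at this position. Nothing measured here explains the step.

On these data alone, it remains open how a plain phenyl, a hexyl chain or a piperidine would read on this nitrogen. As far as these compounds go, whether cyclohexyl would give a similar step alongside 4-chlorophenyl in place of cyclopentyl also remains open.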